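The compounds below may be only part of what the source reports. "The series", "measured", "known", "first", "only" and "open" are said of these compounds alone.

In an ADME assay on HepG2 cells (Homo sapiens) for cytotoxicity, with a stated time of 72 h (a higher number here means that more compound is needed for the effect, a lower number that less compound is needed), three related compounds have been measured. Compound 1 `Cc1cc(NC(=O)Nc2ccc(C)c(Cl)c2)c2ccccc2n1` gives only a limit of the assay, > 25000 nM. Compound 2 `COc1ccc(NC(=O)Nc2cc(C)nc3ccccc23)cc1` likewise gives only a limit, > 25000 nM. Compound 3 `Cc1cc(NC(=O)Nc2cccc(Cl)c2)c2ccccc2n1` is the one member with a number: in this assay compound 3 gives 19000 nM, so it stands as the only number shown. Among the measured compounds shown here, the single step that can be read, an at least 1.3-fold lower number from compound 1 to compound 3 (0.11 log units; that floor lies within the scatter), is small and lies within the scatter; it rests on (the limit of > 25000 nM in this assay, at which 2 of the 3 values shown sit).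

Compound 4 `COc1ccc(NC(=O)Nc2cc(C)nc3ccccc23)cc1Cl` has not yet been measured. Its change from compound 3 is methoxy in place of hydrogen on an aromatic carbon. For the measured compounds named here, no measured step bears directly on this change. Compound 2, which carries the methoxy group without the chloro group, shows only a limit. Compound 1 shows only a limit as well. The values of this series therefore sit at or near the limit, and no step beyond the scatter is expected in this assay. Compound 4 is expected to give about 25000 nM, between 12000 nM and 60000 nM. The expected step is a 1.3-fold higher number from compound 3 to compound 4 (0.12 log units; within the scatter).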

Compound 4, half-maximal effective concentration: > 25000 nM
Compound 4: only a limit was reported; the forecaster's own chance of this, stated with the estimate: 55%; the middle value sits exactly at the limit.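

Methoxy in place of hydrogen, on a carbon ortho to a chloro group and para to a large group, is read here directly for the first time: an at least 1.3-fold higher number from compound 3 to compound 4 (0.11 log units; that floor lies within the scatter) in this assay. Going by these compounds, that figure is only a floor, so the change gives no sign of a lower number, but its true size remains unknown. The steps to compound 4 from compound 2 and from compound 1 cannot be read, and the whole comparison rests on one ceiling: the limit of > 25000 nM in this assay, at which 3 of the 4 values shown sit.

Among the compounds shown here, with compound 3 the only member that has a number, it remains open how far beyond the limit compound 4 truly lies. Also open, on these data alone, is how this assay would respond to an amine or a carboxylic acid on the same carbon in place of methoxy.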